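What a Plain Phenyl Group May Do

The source may hold more compounds than are shown below. What is called first, only, known or untested is meant among the compounds shown, and "the series" means these compounds.

In a functional assay on CCRF-CEM cells (Homo sapiens) for inhibition, read by sulforhodamine B assay, with a stated time of 48 h (a higher number here means a weaker inhibitor of growth, a lower number a stronger inhibitor of growth), compound 1 `COc1cc(-c2nn(-c3cccc(NC(=O)Nc4ccc(Cl)c(Cl)c4)c3)cc2-c2ccncc2)ccc1Cl` gives 1040 nM, compound 2 `COc1cc(-c2nn(-c3cccc(NC(=O)Nc4cccc(C(F)(F)F)c4)c3)cc2-c2ccncc2)ccc1Cl` gives 945 nM and compound 3 `COc1cc(-c2nn(-c3cccc(NC(=O)c4ccc(Cl)c(C(F)(F)F)c4)c3)cc2-c2ccncc2)ccc1Cl` gives 1770 nM. Compound 3 thus stands level with the other two, since the steps to it are a 1.7-fold higher number from compound 1 to compound 3 (0.23 log units; within the scatter) and a 1.9-fold higher number from compound 2 to compound 3 (0.27 log units; within the scatter). Compound 4 `COc1cc(-c2nn(-c3cccc(NC(=O)c4ccccc4)c3)cc2-c2ccncc2)ccc1Cl` brings one change to compound 3: phenyl in place of 4-chloro-3-(trifluoromethyl)phenyl on a carbonyl carbon. The swaps measured so far, such as a 1.1-fold lower number from compound 1 to compound 2 (0.04 log units; within the scatter), stayed small, but each compound in them carries a substituted aryl group, so none directly tests a plain phenyl. A small step with a slight lean towards a weaker inhibitor is therefore expected, though with wide uncertainty. The expected step is a 1.5-fold higher number from compound 3 to compound 4 (0.17 log units; within the scatter). For compound 4 the estimated value is 2600 nM, within an expected range of 900 nM to 7500 nM.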

Compound 4, concentration for 50% growth inhibition: 492 nM
Beside the measured number, compound 4's estimate is 5.3-fold (0.72 log units) above it; the measured number lies below the stated range.
By their numbers in this assay, from the lowest: compounds 4, 2, 1 and 3 (each within the scatter of the next, the first and the last beyond it).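

Removing the chlorine and the trifluoromethyl from the aryl group on the carbonyl carbon, which leaves plain phenyl, gives a 3.6-fold lower number from compound 3 to compound 4 (0.56 log units; beyond the scatter) in this assay, so among these compounds neither substituent is required for growth inhibition. Set against the compounds with an arylamino group on the carbonyl carbon, plain phenyl gives a 1.9-fold lower number from compound 2 to compound 4 (0.28 log units; within the scatter) and a 2.1-fold lower number from compound 1 to compound 4 (0.33 log units; beyond the scatter), so the smaller group at least keeps pace with them.

Whether the chlorine or the trifluoromethyl alone accounts for the difference stays open, as does what an amine or a carboxylic acid on the phenyl would do. Nothing measured here explains why plain phenyl does better than the group it replaces.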